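Thioether-linked pyrimidine series: two values and one expectation

The source may report more compounds than this note shows. Statements on the series, on what has been measured and on what is new or still open speak of the compounds shown alone.

Measured compounds:
compound 1, `CC(C)(C)OC(=O)N1CCN(c2cc(C(F)(F)F)nc(SCc3ccc(C(F)(F)F)cc3)n2)CC1`, 22200 nM
compound 2, `FC(F)(F)c1ccc(CSc2nc(Sc3ncccn3)cc(C(F)(F)F)n2)cc1`, 28600 nM

Both measured compounds were run in a functional assay on MGC-803 cells (Homo sapiens) for inhibition, read by MTT assay, with a stated time of 72 h; on this read-out higher numbers stand for weaker inhibition and lower numbers for stronger inhibition. Compound 1 gives 22200 nM and compound 2 gives 28600 nM in this assay; the two numbers lie within the scatter of each other, so neither compound can be separated from the other on these data. Compound 2 carries a pyrimidin-2-yl group on a sulfur whose other neighbour is an aromatic carbon.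

Compound 3, `FC(F)(F)c1ccc(CSc2nc(Sc3ncc(-c4ccncc4)s3)cc(C(F)(F)F)n2)cc1`, keeps the shared core of compound 2 and differs only at that sulfur: 5-(pyridin-4-yl)-1,3-thiazol-2-yl in place of pyrimidin-2-yl on a sulfur. Within the data shown here, no step between measured compounds is available to calibrate such a change. Because compound 2 shows 28600 nM, the expectation is a step of a 2.4-fold lower number from compound 2 to compound 3 (0.38 log units; beyond the scatter), toward stronger inhibition, of moderate size and not firmly beyond the scatter. Compound 3 is therefore expected to give about 12000 nM in this assay, within a range from 4000 nM to 40000 nM.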

Compound 3, half-maximal inhibitory concentration: 5770 nM
The estimate for compound 3 lay 2.1-fold (0.32 log units) above the measured number, within the range that was stated.
By their numbers in this assay, from the lowest: compound 3; then compounds 1 and 2 (each within the scatter of the next).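

At the sulfur whose other neighbour is an aromatic carbon, the group carried there clearly changes the read-out in this assay: 5-(pyridin-4-yl)-1,3-thiazol-2-yl in place of pyrimidin-2-yl gives a 5.0-fold lower number from compound 2 to compound 3 (0.70 log units; beyond the scatter) toward stronger inhibition. Compound 1 and compound 2 could not show this, as they do not differ in one place and their values lie within the scatter of each other. No measurement here bears on the origin of this step.

As far as these compounds go, the change replaces one aromatic ring with two, so it remains open whether the step follows the 1,3-thiazol-2-yl ring or the pyridin-4-yl group attached to it. An unsubstituted 1,3-thiazol-2-yl group on this sulfur, or a phenyl group in place of the pyridin-4-yl, would separate the two parts.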